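Sulfonyl side chains on the shared core: compound 4

The compounds below may be only part of what the source reports. "The series", "measured", "known", "first", "only" and "open" are said of these compounds alone.

Measured so far in an assay on HeLa cells for inhibition of Indoleamine 2,3-dioxygenase 1 (Homo sapiens), read by spectrophotometry, with a stated time of 24 h; on this read-out lower numbers stand for an effect already at smaller amounts and higher numbers for an effect only at larger amounts of compound:
compound 1 `NNc1nonc1/C(=N/O)Nc1ccc(F)c(Br)c1` gives 556 nM
compound 2 `O=S(=O)(CCNc1nonc1/C(=N/O)Nc1ccc(F)c(Br)c1)N1CCC1` gives 143 nM
compound 3 `NS(=O)(=O)CCCNc1nonc1/C(=N/O)Nc1ccc(F)c(Br)c1` gives 15 nM

Compound 2 stands second highest of the three numbers in this assay. Its nearest neighbour is compound 1, with a 3.9-fold lower number from compound 1 to compound 2 (0.59 log units; beyond the scatter); its furthest is compound 3, with a 9.5-fold lower number from compound 2 to compound 3 (0.98 log units; beyond the scatter). The largest step in the set is a 37-fold lower number from compound 1 to compound 3 (1.57 log units; beyond the scatter).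

Compound 4 `CN(C)S(=O)(=O)CCCNc1nonc1/C(=N/O)Nc1ccc(F)c(Br)c1` is not yet measured. Relative to compound 2 the change is (dimethylsulfamoyl)methyl in place of (azetidin-1-yl)sulfonyl on a saturated chain carbon, two bonds along the chain from a nitrogen on an aromatic ring. This keeps a tertiary sulfonamide, as in compound 2, while lengthening the chain as in compound 3; the step from compound 2 to compound 3 changed both chain length and sulfonamide substitution at once, so it only partly bears on this change. Compound 1 to compound 2 shows what a sulfonyl chain adds over amino, but does not separate the two features either.

In this assay the expected step is therefore a 2.9-fold lower number from compound 2 to compound 4 (0.46 log units; beyond the scatter), a lowering smaller than the step to compound 3 and still beyond the scatter. Compound 4 is estimated at 50 nM, with a range from 15 nM to 150 nM.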

Compound 4, half-maximal effective concentration: 20 nM
Beside the measured number, compound 4's estimate is 2.5-fold (0.40 log units) above it, within the range that was stated.
By their numbers in this assay, from the lowest: compounds 3 and 4 (each within the scatter of the next); then compound 2; then compound 1.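

In this assay, dimethylamino in place of amino on the sulfonyl sulfur gives a 1.3-fold higher number from compound 3 to compound 4 (0.12 log units; within the scatter) and the two groups cannot be told apart, so the low number of compound 3 does not depend on an unsubstituted sulfonamide. With the sulfonamide tertiary at both ends of the comparison, 3-(dimethylsulfamoyl)propyl in place of 2-((azetidin-1-yl)sulfonyl)ethyl gives a 7.2-fold lower number from compound 2 to compound 4 (0.85 log units; beyond the scatter) with the heavy atom count unchanged, so the earlier step to compound 3 need not be read as an effect of the free sulfonamide. Set against the amino group of compound 1, the same side chain gives a 28-fold lower number from compound 1 to compound 4 (1.44 log units; beyond the scatter) and no measurement at hand accounts for any of these steps.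

The step from compound 2 still joins the longer chain with the loss of the four-membered ring, and a 3-((azetidin-1-yl)sulfonyl)propyl group on the shared core would separate the two. Also open, as far as these compounds go, is whether the sulfonyl group itself matters at the end of this chain, which a carboxylic acid or an amine there would test, and how a longer chain would read out.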